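Compound 3 to compound 4: fluoro to trifluoromethyl

This account rests on a few compounds, and the source may have more. Where it says the series, first, only, none or still open, it means among the compounds named here.

Within the data shown here, in an ADME assay on HEK293 cells (Homo sapiens) for cytotoxicity, read by resazurin assay, with a stated time of 48 h (a higher number here means that more compound is tolerated, a lower number that less compound is tolerated), compound 1 (`Cc1ccc(S(=O)(=O)Nc2ccc(-c3nc4ccccc4o3)cc2)cc1`) gives 88000 nM, the only true number in the set so far. Compound 2 (`C=Cc1ccc(S(=O)(=O)Nc2ccc(-c3nc4ccccc4o3)cc2)cc1`) reads > 100000 nM, which is a limit of the assay. Compound 3 (`O=S(=O)(Nc1ccc(-c2nc3ccccc3o2)cc1)c1ccc(F)cc1`) reads > 100000 nM, also a limit. Going by these compounds, compound 3 therefore stands at the limit of > 100000 nM in this assay, at which 2 of the 3 values shown sit, and how far its tolerance extends remains unknown.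

Compound 4 (`O=S(=O)(Nc1ccc(-c2nc3ccccc3o2)cc1)c1ccc(C(F)(F)F)cc1`) carries trifluoromethyl in place of fluoro on an aromatic carbon, para to a large group: trifluoromethyl in place of fluoro on an aromatic carbon.

Three measured steps change the group at this same place. The first two are an at least 1.1-fold higher number from compound 1 to compound 2 (0.05 log units; that floor lies within the scatter) and an at least 1.1-fold higher number from compound 1 to compound 3 (0.05 log units; that floor lies within the scatter), and neither floor lies beyond the scatter. The third is a step that the two limits leave unreadable from compound 2 to compound 3. Going by an at least 1.1-fold higher number from compound 1 to compound 3 (0.05 log units; that floor lies within the scatter), the closest measured swap, no change at this place has yet shown a readable effect, so no step beyond the scatter is expected in this assay, in either direction. The expected change is an at least 1.1-fold lower number from compound 3 to compound 4 (0.04 log units; that floor lies within the scatter). A reading at the limit again is about as likely as a true number. For compound 4 the estimate is 90000 nM, with an expected range from 45000 nM to 180000 nM.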

Compound 4, half-maximal cytotoxic concentration: 94000 nM
Compound 4: the middle estimate sits 1.0-fold (0.02 log units) below what was measured; the measured number falls inside the stated range.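

Compound 4 gives this position its first step with true numbers at both ends in this assay, a 1.1-fold higher number from compound 1 to compound 4 (0.03 log units; within the scatter), so the swap of methyl for trifluoromethyl can be read as a size and not only as a floor, and that size shows no readable effect. Moving from fluoro, with its 1 heavy atom, to trifluoromethyl, with its 4 heavy atoms, also gives no step beyond the scatter: the series shows an at least 1.0-fold lower number from compound 3 to compound 4 (0.02 log units; that floor lies within the scatter), and the swap of vinyl for trifluoromethyl gives an at least 1.0-fold lower number from compound 2 to compound 4 (0.02 log units; that floor lies within the scatter). These last two steps remain floors because compound 2 and compound 3 each stand at a limit and not at a number: the limit of > 100000 nM in this assay, at which 2 of the 4 values shown sit.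

Going by these compounds, how far the tolerance of compound 2 and compound 3 extends stays open, so the true size of the steps from those two compounds to compound 4 is unknown. Also open, on these data alone, is whether any group at this place, such as an amine, a carboxylic acid or a longer chain, would give a step beyond the scatter in this assay.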